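The Oxadiazole of Compound 3 Gives Way to a Chain

A few compounds are considered here, and "the series" means these few. Any claim that something is new, unique, unknown or untested is made for them only; others in the source may bear on it.

Of the compounds shown here, three built on one shared core have been measured in a functional assay on the whole organism (strain Wistar) for inhibition, with Rattus norvegicus as the target, read by paw edema, with stated times of 30 min and 2 h, at a dose of 20 mg/kg; on this read-out lower numbers stand for less inhibition and higher numbers for more inhibition at the one dose given (going by the name of the read-out). Compound 1 `CCOC(=O)C1=C(C)NC(C)=C(C(=O)OCC)C1c1ccc(OCC(=O)Nc2c(C)cccc2C)cc1` gives 47.8%, compound 2 `CCOC(=O)C1=C(C)NC(C)=C(C(=O)OCC)C1c1ccc(OCC(=O)Nc2ccc(C)cc2)cc1` gives 62.2%, and compound 3 `CCOC(=O)C1=C(C)NC(C)=C(C(=O)OCC)C1c1ccc(OCc2nnc(S)o2)cc1` gives 61.7%. Among these three numbers compound 3 stands second highest; the nearest step to it lies a number 0.5 percentage points lower from compound 2 to compound 3 (within the scatter), and the furthest lies a number 13.9 percentage points higher from compound 1 to compound 3 (beyond the scatter). The remaining pair shows a number 14.4 percentage points higher from compound 1 to compound 2 (beyond the scatter).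

Compound 4 `CCOC(=O)C1=C(C)NC(C)=C(C(=O)OCC)C1c1ccc(OCC(=O)NNC(=O)CCC(=O)O)cc1` has not yet been measured. Its difference from compound 3 is this: a group of 11 heavy atoms (5 carbon, 2 nitrogen, 4 oxygen; no ring) in place of a group of 6 heavy atoms (2 carbon, 2 nitrogen, 1 oxygen, 1 sulfur; one five-membered aromatic ring with 3 hetero atoms), on a saturated chain carbon bound to an oxygen on an aromatic ring. The measured steps that touch the same place are the two that brought in the 5-sulfanyl-1,3,4-oxadiazol-2-yl group, a number 13.9 percentage points higher from compound 1 to compound 3 (beyond the scatter) and a number 0.5 percentage points lower from compound 2 to compound 3 (within the scatter). One of them is modest and beyond the scatter, the other within it, so this place has so far accepted different groups without a fixed direction. Among the compounds with values here, no measured step exchanges the 5-sulfanyl-1,3,4-oxadiazol-2-yl group for a group with no ring, so nothing points to a large move either way. Compound 4 is expected to show a step of a number 4.7 percentage points lower from compound 3 to compound 4 (within the scatter) that stays within the scatter. The estimate for compound 4 in this assay is 57%, expected to fall between 42% and 70%.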

Compound 4, a percentage reported as inhibition, in the whole organism at one dose (the size of the read-out at that dose, not a potency): 57.8%
Beside the measured number, compound 4's estimate is 0.8 percentage points below it; measured number inside the range.
By their numbers in this assay, from the lowest: compounds 1, 4, 3 and 2 (each within the scatter of the next, the first and the last beyond it).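

At this place, on a saturated chain carbon bound to an oxygen on an aromatic ring, a group with no ring can stand in for the 5-sulfanyl-1,3,4-oxadiazol-2-yl group in this assay, with a number 3.9 percentage points lower from compound 3 to compound 4 (within the scatter). On the amide-type nitrogen, ((2-carboxyethyl)carbonyl)amino in place of 4-methylphenyl gives a number 4.4 percentage points lower from compound 2 to compound 4 (within the scatter), and in place of 2,6-dimethylphenyl it gives a number 10 percentage points higher from compound 1 to compound 4 (within the scatter), so among these compounds neither a ring at the far side of this linker nor a phenyl group on that nitrogen is required to stay within the scatter of the others. Nothing measured here bears on why these steps come out as they do.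

As far as these compounds go, what a methyl ester or a primary amine in place of the carboxylic acid of compound 4 would give in this assay remains open, as does the outcome of a shorter or longer chain in that group. The read-out also comes from one dose, so it gives the size of the effect at that dose and leaves any difference in potency among these compounds unresolved.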